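The source may report more compounds than this note shows. Statements on the series, on what has been measured and on what is new or still open speak of the compounds shown alone.

Of the compounds shown here, two have been tested. Compound 1 `C[C@H](Nc1nc(-c2ccccc2)nc2ccc(Br)cc12)C(=O)O` carries a bromine on its core, while compound 2 `CC[C@H](C)[C@H](Nc1nc(-c2ccccc2)nc2ccccc12)C(=O)O` carries none. In a functional assay on the whole organism (strain Wistar) for inhibition, with Rattus norvegicus as the target, read by paw edema, at a dose of 100 mg/kg by the oral route (on this read-out lower numbers stand for less inhibition and higher numbers for more inhibition at the one dose given (going by the name of the read-out)), compound 1 gives 0%, and in this assay compound 2 gives 4.1%, the higher of the two numbers, though the gap to compound 1 lies within the scatter. Compound 3 `CC[C@H](C)[C@H](Nc1nc(-c2ccccc2)nc2ccc(Br)cc12)C(=O)O` differs from compound 2 by bromo in place of hydrogen on an aromatic carbon. Since compound 1, which also carries this bromine, gives 0%, the step from compound 2 to compound 3 is expected to be none beyond the scatter, which is a number 2.1 percentage points lower from compound 2 to compound 3 (within the scatter). Compound 3 is therefore estimated at 2%, between 0% and 12%.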

Compound 3, a percentage reported as inhibition, in the whole organism at one dose (the size of the read-out at that dose, not a potency): 0%
For compound 3 the middle estimate is 2 percentage points above the measured one, within the range that was stated.
By their numbers in this assay, from the lowest: compounds 1, 3 and 2 (each within the scatter of the next).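

In this assay, bromo in place of hydrogen on this aromatic carbon gives a number 4.1 percentage points lower from compound 2 to compound 3 (within the scatter) and sec-butyl in place of methyl on the saturated chain carbon gives no change at the digits printed from compound 1 to compound 3 (within the scatter) in the series. Neither change therefore moves the read-out beyond the scatter, and with the bromine present the two chains are not told apart. No measurement at hand offers an explanation for this result. Still open is whether a methoxy group on this aromatic carbon, or an amide in place of the carboxylic acid, would give a read-out beyond the scatter of these compounds.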